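This account rests on a few compounds, and the source may have more. Where it says the series, first, only, none or still open, it means among the compounds named here.

Values in a functional assay on SK-OV-3 cells (Homo sapiens) for cytotoxicity; on this read-out lower numbers stand for stronger inhibition and higher numbers for weaker inhibition:
- compound 1 `C=C/C=C\[C@H](C)[C@H](OC(N)=O)[C@@H](C)[C@H](O)[C@@H](C)C/C(C)=C\[C@H](C)[C@@H](O)[C@@H](C)/C=C\CCc1ccc(C)c(F)c1`: 1000 nM
- compound 2 `C=C/C=C\[C@H](C)[C@H](OC(N)=O)[C@@H](C)[C@H](O)[C@@H](C)C/C(C)=C\[C@H](C)[C@@H](O)[C@@H](C)/C=C\CCc1ccccc1`: 350 nM

Compound 2 holds the lower number of the two, at 350 nM. The open case is compound 3 `C=C/C=C\[C@H](C)[C@H](OC(N)=O)[C@@H](C)[C@H](O)[C@@H](C)C/C(C)=C\[C@H](C)[C@@H](O)[C@@H](C)/C=C\CCc1cc(O)cc(O)c1`, which carries this change: 3,5-dihydroxyphenyl in place of phenyl on a saturated chain carbon, two bonds along the chain from a double-bonded chain carbon. In short, 3,5-dihydroxyphenyl stands in place of phenyl on a saturated chain carbon, two bonds along the chain from a double-bonded chain carbon. Within the data shown here, only one measured step bears on this place: a 2.9-fold lower number from compound 1 to compound 2 (0.46 log units; beyond the scatter), where phenyl replaces 3-fluoro-4-methylphenyl. That step is modest but beyond the scatter, and there the substituted ring has the higher number. No ring with hydroxy groups has been measured, so this guide is weak. A modest move to a higher number is expected, of similar size. The expected step is a 1.7-fold higher number from compound 2 to compound 3 (0.23 log units; within the scatter). For compound 3 the estimated value is 600 nM, with an expected range of 150 nM to 2400 nM.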

Compound 3, half-maximal inhibitory concentration: 40 nM
For compound 3 the middle estimate is 15-fold (1.18 log units) above the measured one; the whole stated range lies above it.
By their numbers in this assay, from the lowest: compound 3; then compound 2; then compound 1.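

In this assay, the group on this saturated chain carbon can push the number down as well as up: 3,5-dihydroxyphenyl in place of phenyl gives an 8.8-fold lower number from compound 2 to compound 3 (0.94 log units; beyond the scatter), whereas the earlier step showed only a substituted ring with the higher number. Measured against 3-fluoro-4-methylphenyl, the same ring gives a 25-fold lower number from compound 1 to compound 3 (1.40 log units; beyond the scatter), so substitution on this ring has no single direction here: compound 1 lies above compound 2 and compound 3 lies below it. Nothing at hand accounts for the size or direction of these steps.

The compounds shown leave open whether a single hydroxy group, as in 3-hydroxyphenyl, is enough for this step. They also leave open whether methoxy groups, as in 3,5-dimethoxyphenyl, or amines on the ring would give the same result.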